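A few compounds are considered here, and "the series" means these few. Any claim that something is new, unique, unknown or untested is made for them only; others in the source may bear on it.

Of the compounds shown here, three of one series have been tested in a functional assay on HEp-2 cells (Homo sapiens) for cytotoxicity, read by sulforhodamine B assay, with a stated time of 48 h; a higher number here means a weaker inhibitor, a lower number a stronger inhibitor. Compound 1 `CC(=O)N1N=C(c2cccc([N+](=O)[O-])c2)CC1c1ccccc1` gives 8930 nM, compound 2 `COc1cc(C2CC(c3cccc4ccccc34)=NN2C(C)=O)cc(OC)c1OC` gives 1010 nM, and compound 3 `O=CCN1N=C(c2ccc3ccccc3c2)CC1c1cccc([N+](=O)[O-])c1` gives 3870 nM. Compound 3 thus sits second highest of the three numbers: compound 1 lies higher by a gap beyond the usual scatter, and compound 2 lies lower by a larger gap, also beyond the scatter. Compound 4 `COc1ccc(C2CC(c3ccc4ccccc4c3)=NN2CC=O)cc1` has not yet been measured; it differs from compound 3 in one place, (4-methoxyphenyl in place of 3-nitrophenyl on a saturated ring carbon). For the measured compounds named here, no measured pair shows this exact exchange, so the expected size of the step rests only on compound 2, the one methoxy-bearing compound, which with 1010 nM gives the lowest number. A moderate decrease is therefore expected, a 1.5-fold lower number from compound 3 to compound 4 (0.19 log units; within the scatter), so that compound 4 is estimated at 2500 nM, within a range of 1000 nM to 6000 nM.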

Compound 4, half-maximal inhibitory concentration: 3230 nM
The estimate for compound 4 lay 1.3-fold (0.11 log units) below the measured number; the measured number falls inside the stated range.
By their numbers in this assay, from the lowest: compound 2; then compounds 4 and 3 (each within the scatter of the next); then compound 1.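

At this saturated ring carbon, 4-methoxyphenyl in place of 3-nitrophenyl gives a 1.2-fold lower number from compound 3 to compound 4 (0.08 log units; within the scatter) in this assay. The two compounds therefore cannot be told apart here, even though the exchange swaps one substituted aromatic ring for a quite different one. No measurement shown bears on why these two groups read alike.

Going by these compounds, whether a phenyl ring carrying an amine or a carboxylic acid, or a plain methyl at this carbon, would move the number beyond the scatter remains open. So does whether this exchange reads the same with another group in place of formylmethyl.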